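A few compounds are considered here, and "the series" means these few. Any claim that something is new, unique, unknown or untested is made for them only; others in the source may bear on it.

Measured compounds:
compound 1 `CC(C)[C@H]1CC[C@@]2(CO2)[C@H]2C(=O)OCC(C(=O)OCc3ccc(-c4ccccc4)o3)=C[C@H]12` — in a functional assay on A-375 cells (Homo sapiens) for inhibition, with a stated time of 72 h (on this read-out lower numbers stand for stronger inhibition and higher numbers for weaker inhibition), compound 1 gives 1310 nM
compound 2 `CC(C)[C@H]1CC[C@@]2(CO2)[C@H]2C(=O)OCC(C(=O)O)=C[C@H]12` — in this assay compound 2 gives 1340 nM

Compound 2 stands beside compound 1 with the two numbers so close that the gap lies within the usual scatter; the two cannot be told apart on this read-out, even though the ester of compound 1 is replaced by a free carboxy group in compound 2. Compound 3 `COC(=O)C1=C[C@@H]2[C@@H](C(C)C)CC[C@@]3(CO3)[C@H]2C(=O)OC1` has not yet been measured. It differs from compound 2 in one place: methyl in place of hydrogen on an oxygen next to a carbonyl group. Since swapping a large ester for the free acid left this assay unchanged between compound 1 and compound 2, the small change to compound 3 is expected to give no step beyond the scatter in either direction. Compound 3 is therefore expected to give about 1300 nM, from 600 nM to 2800 nM. This estimate corresponds to an expected step of a 1.0-fold lower number from compound 2 to compound 3 (0.01 log units; within the scatter).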

Compound 3, half-maximal inhibitory concentration: 4090 nM
Compound 3: the middle estimate sits 3.1-fold (0.50 log units) below what was measured; the measured number lies above the stated range.
By their numbers in this assay, from the lowest: compounds 1 and 2 (each within the scatter of the next); then compound 3.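

In this assay the carboxy group of compound 2 proves to be a place where a small change registers: methyl in place of hydrogen on an oxygen next to a carbonyl group, which turns carboxy into methoxycarbonyl, gives a 3.1-fold higher number from compound 2 to compound 3 (0.48 log units; beyond the scatter) and so weakens inhibition. Among the compounds shown here, this is the first step beyond the scatter between compounds that differ in one place, and it shows that one added carbon at this oxygen is enough to move the read-out. Nothing available bears on the reason for this step.

Going by these compounds, whether an ethyl group or a longer chain on the same oxygen would weaken inhibition further remains open. So does the effect of an amide in place of the carboxy group, and this single pair sets no trend.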